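From 2-hydroxy-4-methoxyphenyl to 2-hydroxy-3-methoxyphenyl

This account rests on a few compounds, and the source may have more. Where it says the series, first, only, none or still open, it means among the compounds named here.

Compound 1 `O=C(C=C1CCN(C(=O)c2ccccc2O)CC1)N[C@@H]1CCN(Cc2ccc3cc(F)ccc3c2)C1` reads < 64 mL/min/kg in an in vitro ADME assay on microsomes from liver (Homo sapiens) for metabolic stability (on this read-out lower numbers stand for slow clearance and higher numbers for fast clearance), which is a limit of the assay and not a number.

Among the compounds with values here, compound 2 `COc1ccc(C(=O)N2CCC(=CC(=O)N[C@@H]3CCN(Cc4ccc5cc(F)ccc5c4)C3)CC2)c(O)c1` gives 232 mL/min/kg in this assay, the only actual number so far.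

Compound 3 `COc1cccc(C(=O)N2CCC(=CC(=O)N[C@@H]3CCN(Cc4ccc5cc(F)ccc5c4)C3)CC2)c1O` is its isomer: 2-hydroxy-3-methoxyphenyl in place of 2-hydroxy-4-methoxyphenyl on a carbonyl carbon. In words, 2-hydroxy-3-methoxyphenyl stands in place of 2-hydroxy-4-methoxyphenyl on a carbonyl carbon.

Within the data shown here, one measured step bears on this: an at least 3.6-fold higher number from compound 1 to compound 2 (0.55 log units; beyond the scatter), with methoxy in place of hydrogen on an aromatic carbon. Compound 3 still carries the methoxy of that step, so a return to the limit of compound 1 is not the expected outcome. Among the measured compounds shown here, no measured step moves a methoxy, which leaves the direction open.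

The expected change is small, a 1.3-fold lower number from compound 2 to compound 3 (0.11 log units; within the scatter), and no shift beyond the scatter is expected. Compound 3 is estimated at 180 mL/min/kg, with an expected range of 75 mL/min/kg to 380 mL/min/kg.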

Compound 3, clearance: 162 mL/min/kg
Estimate against measurement, compound 3: 1.1-fold (0.05 log units) above; measured number inside the range.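

In this assay, 2-hydroxy-3-methoxyphenyl in place of 2-hydroxy-4-methoxyphenyl on the carbonyl carbon gives a 1.4-fold lower number from compound 2 to compound 3 (0.16 log units; within the scatter), so these two placings of the methoxy are not separated on this read-out. The rise on adding a methoxy to the aromatic ring now appears in both isomers, not only in one, with an at least 2.5-fold higher number from compound 1 to compound 3 (0.40 log units; beyond the scatter). Compound 1 carries a limit and not a number, so the full size of both methoxy steps stays unknown: the limit of < 64 mL/min/kg in this assay, at which 1 of the 3 values shown sits.

Left open is whether fluorine, an amine or a carboxylic acid on the same aromatic ring would give a number like those of compound 2 and compound 3. Also open, on these data alone, is whether ethoxy, a longer chain, would follow methoxy on this read-out.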